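Aryl Swap on the Triazole: Expected Inactivity on L02 Cells

The compounds below may be only part of what the source reports. "The series", "measured", "known", "first", "only" and "open" are said of these compounds alone.

Compound 1 `N#CC1=C(N)Oc2c(c3nc4ccccc4nc3c3ccccc23)C12C(=O)N(Cc1cnnn1-c1ccc(F)cc1)c1ccccc12`: > 50000 nM in an ADME assay on L02 cells (Homo sapiens) for antiproliferative activity, read by MTT assay, with a stated time of 48 h; a lower number here means a stronger inhibitor, a higher number a weaker inhibitor
Compound 2 `Cc1ccc(-n2nncc2CN2C(=O)C3(C(C#N)=C(N)Oc4c3c3nc5ccccc5nc3c3ccccc43)c3ccccc32)cc1Cl`: > 50000 nM in this assay
Compound 3 `Cc1ccccc1-n1nncc1CN1C(=O)C2(C(C#N)=C(N)Oc3c(N)cc4nc5ccccc5nc4c32)c2ccccc21`: > 50000 nM in this assay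

Each of these three values is a limit of the assay, not a number. Compound 3 therefore stands at the limit where every measured value sits (the limit of > 50000 nM in this assay, at which 3 of the 3 values shown sit). Compound 4 `Cc1ccc(-n2nncc2CN2C(=O)C3(C(C#N)=C(N)Oc4c(N)cc5nc6ccccc6nc5c43)c3ccccc32)cc1Cl` differs from compound 3 in one place: 3-chloro-4-methylphenyl in place of 2-methylphenyl on an aromatic nitrogen. Among the measured compounds shown here, the only measured step of this kind, a step that the two limits leave unreadable from compound 1 to compound 2, runs between two limits, so its size cannot be read. No shift beyond the scatter is expected. Compound 4 is expected to give 50000 nM, between 20000 nM and 120000 nM, in this assay. The expected step is a number no higher from compound 3 to compound 4 (the limit leaves the size open), most likely another limit rather than a number.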

Compound 4, half-maximal inhibitory concentration: > 50000 nM
Compound 4: only a limit was reported; the forecaster's own chance of this, stated with the estimate: 85%; the middle value lies on the limit itself.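

No step can be read between compound 3 and compound 4, as each gives only a limit in this assay. The compounds shown leave open whether the group on the aromatic nitrogen changes the activity at all, with every value at one limit: the limit of > 50000 nM in this assay, at which 4 of the 4 values shown sit.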